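The source may report more compounds than this note shows. Statements on the series, on what has been measured and on what is new or still open speak of the compounds shown alone.

In a functional assay on K562 cells (Homo sapiens) for cytotoxicity, read by MTT assay, with a stated time of 72 h (on this read-out higher numbers stand for weaker inhibition and lower numbers for stronger inhibition), compound 3 `COCOc1cc(/C=C/C(=O)OCC(=O)Nc2nccs2)ccc1OCc1ccccc1` gives only a limit, > 200000 nM. Compound 1 `COCOc1cc(/C=C/C(=O)OCC(=O)Nc2ccc(OC)cc2)ccc1OCc1ccccc1` likewise gives only a limit, > 200000 nM. Compound 2 `COCOc1cc(/C=C/C(=O)OCC(=O)NN2CCOCC2)ccc1OCc1ccccc1` gives 32400 nM; the step of an at least 6.1-fold higher number from compound 2 to compound 3 (0.79 log units; beyond the scatter) is at least modest, and an at least 6.1-fold lower number from compound 1 to compound 2 (0.79 log units; beyond the scatter) runs the same way, whereas a step that the two limits leave unreadable from compound 1 to compound 3 cannot be read because both ends sit at the limit of > 200000 nM in this assay, at which 2 of the 3 values shown sit. Compound 4 `COCOc1cc(/C=C/C(=O)OCC(=O)NCc2ccco2)ccc1OCc1ccccc1` differs from compound 3 by (furan-2-yl)methyl in place of 1,3-thiazol-2-yl on an amide-type nitrogen. On these data alone, of the replacements of 1,3-thiazol-2-yl on this amide-type nitrogen, only morpholin-4-yl has been followed in this assay, and it lowered the number; whether (furan-2-yl)methyl does the same is untested. For compound 4 the number in this assay is therefore expected at 100000 nM, between 30000 nM and 300000 nM, a step of an at least 2.0-fold lower number from compound 3 to compound 4 (0.30 log units; that floor lies within the scatter) that is expected to be no more than modest and may well end in a limit again.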

Compound 4, half-maximal inhibitory concentration: 300 nM
Compound 4: middle estimate off by 330-fold (2.52 log units), on the high side, outside the stated range (below it).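

In this assay, for the compounds shown here, this amide-type nitrogen proves far more sensitive than the earlier compounds showed: (furan-2-yl)methyl gives an at least 660-fold lower number from compound 3 to compound 4 (2.82 log units; beyond the scatter), an at least 660-fold lower number from compound 1 to compound 4 (2.82 log units; beyond the scatter) and a 110-fold lower number from compound 2 to compound 4 (2.03 log units; beyond the scatter). Compound 4 is the most potent of the four, and morpholin-4-yl is no longer the only replacement that lowers the number. The steps starting from compound 1 and compound 3 are floors, not sizes: the limit of > 200000 nM in this assay, at which 2 of the 4 values shown sit.

Open, on these data alone, is whether the gain follows the furan ring or its methyl link. A benzyl group or a (thiophen-2-yl)methyl group on this nitrogen would help separate the two.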